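A few compounds are considered here, and "the series" means these few. Any claim that something is new, unique, unknown or untested is made for them only; others in the source may bear on it.

Compound 1 `C[C@H]1C[C@@H](C(N)=O)N(Cc2ccc(OCc3cccc(F)c3)cc2)C1` gives the lowest of the two numbers recorded in an assay on Sf9 cells for inhibition of Amine oxidase [flavin-containing] A (Homo sapiens), with stated times of 15 min and 60 min (on this read-out lower numbers stand for stronger inhibition and higher numbers for weaker inhibition), at 27500 nM. Its stereoisomer compound 2 `C[C@@H]1C[C@@H](C(N)=O)N(Cc2ccc(OCc3cccc(F)c3)cc2)C1` gives 42200 nM, and the step of a 1.5-fold higher number from compound 1 to compound 2 (0.19 log units; within the scatter) rests on (the fact that compounds 1 and 2 differ only in the configuration as drawn). Compound 3 `NC(=O)[C@@H]1C[C@H](O)CN1Cc1ccc(OCc2cccc(F)c2)cc1` differs from compound 1 by hydroxy in place of methyl on a saturated ring carbon. Among the measured compounds shown here, the only measured step changes configuration alone and does not bear on this exchange, so no direction can be read from it. The expected shift a 1.3-fold higher number from compound 1 to compound 3 (0.10 log units; within the scatter) is therefore none beyond the scatter. Compound 3 is estimated at 35000 nM, with a range from 10000 nM to 120000 nM.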

Compound 3, half-maximal inhibitory concentration: 84500 nM
Compound 3: middle estimate off by 2.4-fold (0.38 log units), on the low side, and the stated range covers the measured number.
By their numbers in this assay, from the lowest: compounds 1, 2 and 3 (each within the scatter of the next, the first and the last beyond it).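

In this assay, among the compounds shown here, the exchange of methyl for hydroxy on this saturated ring carbon gives a 3.1-fold higher number from compound 1 to compound 3 (0.49 log units; beyond the scatter) and is the only step so far to go beyond the scatter. This ring carbon therefore responds to a change of group, whereas the change of configuration alone between compounds 1 and 2 stayed within the scatter. Nothing measured here bears on why the hydroxy exchange raises the number. As far as these compounds go, whether an amine, a methoxy or an ethyl group on this carbon would move the number further remains open. So does how a fluorine would compare with methyl and hydroxy there.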